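A few compounds are considered here, and "the series" means these few. Any claim that something is new, unique, unknown or untested is made for them only; others in the source may bear on it.

Compound 1, `COc1ccc(CNC(=N)[C@@H]2CCC(=O)N2Cc2ccccc2[N+](=O)[O-])cc1`: in a functional assay on SH-SY5Y cells (Homo sapiens) for cytotoxicity, read by MTT assay, with stated times of 8 h, 30 min and 12 h, tested at 0.5 uM (a higher number here means a stronger effect of the compound at the concentration tested, a lower number a weaker effect), compound 1 gives 21.1%.
Compound 2, `COc1ccc(CNC(=N)[C@@H]2CCC(=O)N2Cc2ccc(F)cc2)cc1`: in this assay compound 2 gives 36.7%.

Compound 2 holds the higher of the two numbers. Within the data shown here, the only measured step is a number 15.6 percentage points higher from compound 1 to compound 2 (beyond the scatter), which exchanged one whole aryl group for another. Compound 3, `COc1ccc(CNC(=N)[C@@H]2CCC(=O)N2Cc2ccc(OC)cc2)cc1`, differs from compound 2 by a smaller change: methoxy in place of fluoro on an aromatic carbon. Among the measured compounds shown here, no measured step swaps fluoro for methoxy, so that single step offers little guidance here. Compound 3 is therefore expected to show a step of a number 1.7 percentage points lower from compound 2 to compound 3 (within the scatter) in this assay that stays within the scatter. The estimate for compound 3 is 35%, ranging from 20% to 50%.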

Compound 3, a percentage reported as activity, at one concentration (the size of the read-out at that concentration, not a potency): 24.8%
Compound 3: the middle estimate sits 10.2 percentage points above what was measured, within the range that was stated.
By their numbers in this assay, from the lowest: compounds 1 and 3 (each within the scatter of the next); then compound 2.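

On this aromatic carbon, para to a large group, a small exchange of substituent matters: methoxy in place of fluoro gives a number 11.9 percentage points lower from compound 2 to compound 3 (beyond the scatter) in this assay. Replacing the 2-nitrophenyl group with 4-methoxyphenyl gives a number 3.7 percentage points higher from compound 1 to compound 3 (within the scatter), so these two aryl groups cannot be told apart here, and only the 4-fluorophenyl group of compound 2 stands apart. Nothing available explains why the fluoro compound differs. The compounds shown leave open whether chloro, hydroxyl or an amine at this carbon would match fluoro or methoxy.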